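The source may hold more compounds than are shown below. What is called first, only, known or untested is meant among the compounds shown, and "the series" means these compounds.

Measured so far:
Compound 1 `COc1cc(CCCCC(C)(C)O)oc(=O)c1C`: > 200000 nM
Compound 2 `Cc1c(O)cc(CCCC(C)C)oc1=O`: > 200000 nM

In a functional assay on HeLa cells (Homo sapiens) for cytotoxicity, read by MTT assay (on this read-out lower numbers stand for stronger inhibition and higher numbers for weaker inhibition), compound 1 gives only a limit, > 200000 nM. Compound 2 likewise gives only a limit in this assay, > 200000 nM. Compound 2 therefore stands at the limit of > 200000 nM in this assay, at which 2 of the 2 values shown sit, with no measured number to set it against. Compound 3 `CCC(C)CCCCc1cc(O)c(C)c(=O)o1` differs from compound 2 in one place: 2-methylbutyl in place of isopropyl on a saturated chain carbon, three bonds along the chain from an aromatic carbon. Among the measured compounds shown here, no step between two measured compounds is available to weigh this change. Since both measured values sit at the same limit, no shift beyond the scatter is expected, and the expected step is a step that the limit leaves unreadable from compound 2 to compound 3. Compound 3 is estimated at 250000 nM, within a range from 100000 nM to 600000 nM, most likely reported again only as a limit.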

Compound 3, half-maximal inhibitory concentration: > 200000 nM
Compound 3 ended at the assay's limit (the forecaster's own chance of this, stated with the estimate: 85%); the middle value lies beyond the limit too.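

No step can be read between compound 2 and compound 3, because both stop at the same limit: the limit of > 200000 nM in this assay, at which 3 of the 3 values shown sit.

The compounds shown leave open whether any change to the shared core would give a measurable value in this assay.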